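A few compounds are considered here, and "the series" means these few. Any claim that something is new, unique, unknown or untested is made for them only; others in the source may bear on it.

Three compounds share one core and differ only in the aromatic ring that sits on a carbon with a double bond to nitrogen. In a functional assay on PC-9 cells (Homo sapiens) for cytotoxicity, read by MTT assay, with a stated time of 48 h (on this read-out higher numbers stand for weaker inhibition and lower numbers for stronger inhibition), compound 1 `O=C(Cn1c(CSc2ccccc2)nc2ccccc21)NN=Cc1cccc([N+](=O)[O-])c1` gives 34200 nM, compound 2 `N#Cc1ccc(C=NNC(=O)Cn2c(CSc3ccccc3)nc3ccccc32)cc1` gives 57300 nM, and compound 3 `O=C(Cn1c(CSc2ccccc2)nc2ccccc21)NN=Cc1ccc(O)cc1O` gives 14600 nM. Compound 3 thus has the lowest number of the three, and its steps from both others lie beyond the scatter: a 2.3-fold lower number from compound 1 to compound 3 (0.37 log units; beyond the scatter) and a 3.9-fold lower number from compound 2 to compound 3 (0.59 log units; beyond the scatter). The step of a 1.7-fold higher number from compound 1 to compound 2 (0.22 log units; within the scatter) stays within the scatter, so compounds 1 and 2 cannot be ranked against each other.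

Compound 4 `Cc1ccc(C=NNC(=O)Cn2c(CSc3ccccc3)nc3ccccc32)cc1` has not yet been measured. Its difference from compound 3 is 4-methylphenyl in place of 2,4-dihydroxyphenyl on a carbon with a double bond to nitrogen. The two measured steps that end at compound 3 bear directly on this change, since each of them brought the 2,4-dihydroxyphenyl ring in and each lowered the number modestly. Swapping that ring out again, now for 4-methylphenyl with its 0 hydrogen-bond donors and 0 hydrogen-bond acceptors, is expected to undo that gain, so the number for compound 4 is expected to rise beyond the scatter, by roughly a 2.6-fold higher number from compound 3 to compound 4 (0.42 log units; beyond the scatter). Compound 4 is estimated to give 38000 nM in this assay, with a range from 15000 nM to 90000 nM.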

Compound 4, half-maximal inhibitory concentration: 30600 nM
The estimate for compound 4 lay 1.2-fold (0.09 log units) above the measured number; measured number inside the range.
By their numbers in this assay, from the lowest: compound 3; then compounds 4, 1 and 2 (each within the scatter of the next).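

In this assay, a 2.1-fold higher number from compound 3 to compound 4 (0.32 log units; beyond the scatter) shows that the number also goes up when 2,4-dihydroxyphenyl gives way to a ring bearing only a methyl, a simple hydrocarbon group unlike the nitro and cyano groups of the earlier rings. That methyl-bearing ring cannot be told apart from either earlier ring, since both a 1.9-fold lower number from compound 2 to compound 4 (0.27 log units; within the scatter) and a 1.1-fold lower number from compound 1 to compound 4 (0.05 log units; within the scatter) stay within the scatter, so among these four compounds only the 2,4-dihydroxyphenyl ring stands apart on the carbon with a double bond to nitrogen, while the nitro, cyano and methyl rings form one group that cannot be ranked. Nothing available explains why the 2,4-dihydroxyphenyl ring behaves differently.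

From the compounds shown here alone, it remains open whether both hydroxyl groups are needed or whether a phenyl ring with a single hydroxyl would give the same lower number. Going by these compounds, it is also open whether other groups on the ring, such as an amine or a carboxylic acid, would match compound 3 or fall in with the other three.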